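The compounds below may be only part of what the source reports. "The series", "measured", "known", "first", "only" and "open" are said of these compounds alone.

Measured compounds:
compound 1, `COc1ccc(S(=O)(=O)N(CCN=[N+]=[N-])[C@@H](C(=O)NO)C(C)C)cc1` — in an assay on isolated protein for inhibition of matrix metalloproteinase-9 (Homo sapiens), read by fluorescence, with a stated time of 30 min (on this read-out higher numbers stand for weaker inhibition and lower numbers for stronger inhibition), compound 1 gives 6 nM
compound 2, `Cc1ccc(S(=O)(=O)N(CCN=[N+]=[N-])[C@@H](C(=O)NO)C(C)C)cc1` — in this assay compound 2 gives 4 nM

Going by the values given here, compound 2 has the lowest of the two numbers, but its only neighbour is compound 1, and the step of a 1.5-fold lower number from compound 1 to compound 2 (0.18 log units; within the scatter) lies within the scatter, so the two compounds cannot be told apart on these data.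

Compound 3, `Cc1ccc(S(=O)(=O)N(CCn2cc(CCCF)nn2)[C@@H](C(=O)NO)C(C)C)cc1`, has not yet been measured. It differs from compound 2 in one place: a group of 9 heavy atoms (5 carbon, 3 nitrogen, 1 fluorine; one five-membered aromatic ring with 3 hetero atoms) in place of a group of 3 heavy atoms (3 nitrogen; no ring), on a saturated chain carbon, two bonds along the chain from a sulfonamide nitrogen. The azido group and its replacement sit on a saturated chain carbon, two bonds along the chain from a sulfonamide nitrogen.

Among the compounds with values here, the only measured step, a 1.5-fold lower number from compound 1 to compound 2 (0.18 log units; within the scatter), concerns an exchange of methyl for methoxy on an aromatic carbon, a different place in the molecule, so no measured step bears on the change from compound 2 to compound 3. Within the data shown here, with no step to guide the size or direction, the step of a 1.5-fold higher number from compound 2 to compound 3 (0.18 log units; within the scatter) is expected to stay within the scatter, with a wide range to allow for the large new group. Compound 3 is therefore estimated at 6 nM, with a range from 1.5 nM to 25 nM.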

Compound 3, half-maximal inhibitory concentration: 3 nM
The estimate for compound 3 lay 2.0-fold (0.30 log units) above the measured number, and the stated range covers the measured number.
By their numbers in this assay, from the lowest: compounds 3, 2 and 1 (each within the scatter of the next).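

In this assay, the exchange of the azido group for a group of 9 heavy atoms with one five-membered aromatic ring with 3 hetero atoms gives a 1.3-fold lower number from compound 2 to compound 3 (0.12 log units; within the scatter). Going by these compounds alone, this is the first reading at this place, on a saturated chain carbon, two bonds along the chain from a sulfonamide nitrogen, since the earlier step concerned only an aromatic carbon. It shows that a much larger group with a ring can stand here and the number stays within the scatter of that of the small azido group, at least on this core. No measurement shown here explains this result.

With only these two groups at this place, neither the ring nor the fluorine can be credited or cleared separately, and the same ring carrying a plain propyl chain, or a longer chain ending in fluorine, would be needed to tell them apart. As far as these compounds go, a group with a net charge, such as an amine or a carboxylic acid at the end of the chain, also remains open, as does whether the same exchange behaves alike with the methoxy group of compound 1 in place of the methyl.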